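This account rests on a few compounds, and the source may have more. Where it says the series, first, only, none or still open, it means among the compounds named here.

Compound 2 `CC(C)COc1cccc2occ(Cc3coc4ccccc4c3=O)c(=O)c12` gives 1720 nM.
Compound 1 `O=c1c(/C=C/c2coc3ccccc3c2=O)coc2ccccc12` gives > 10000 nM, a limit of the assay.
Compound 3 `O=c1c(CCc2coc3ccccc3c2=O)coc2ccccc12` gives > 10000 nM, also a limit of the assay.

In a functional assay on PC-3 cells (Homo sapiens) for antiproliferative activity, read by XTT assay (a higher number here means a weaker inhibitor, a lower number a stronger inhibitor), compound 2 holds the only finished number shown; the other two compounds stop at the limit of > 10000 nM in this assay, at which 2 of the 3 values shown sit, so compound 2 stands apart from them. Compound 4 `COc1cccc2occ(Cc3coc4ccccc4c3=O)c(=O)c12` differs from compound 2 by hydrogen in place of isopropyl on a saturated chain carbon bound to an oxygen on an aromatic ring, isobutoxy becoming methoxy. For the measured compounds named here, no measured pair shows this change, so its effect is open; a modest loss, close to the edge of the usual scatter, is expected as the step of a 1.9-fold higher number from compound 2 to compound 4 (0.27 log units; within the scatter). Compound 4 is accordingly estimated at 3200 nM, with a range from 900 nM to 12000 nM.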

Compound 4, half-maximal inhibitory concentration: 3490 nM
Compound 4: middle estimate off by 1.1-fold (0.04 log units), on the low side; low and high end bracket the measured number.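

In this assay, for the compounds shown here, this is the first pair that differs only at this place, and cutting isobutoxy back to methoxy gives a 2.0-fold higher number from compound 2 to compound 4 (0.31 log units; beyond the scatter), a modest step just beyond the usual scatter. Compound 4 still gives a finished number, so the isopropyl part is not needed for measurable activity on these cells. Nothing shown gives a cause for this step.

From the compounds shown here alone, how a longer chain or an amine on this saturated chain carbon would read remains open. So does the same core with hydrogen in place of the whole methoxy group.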